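A few compounds are considered here, and "the series" means these few. Any claim that something is new, unique, unknown or untested is made for them only; others in the source may bear on it.

Of the compounds shown here, three from this series have been tested in an assay for inhibition of Fatty-acid amide hydrolase 1 (Rattus norvegicus) (a higher number here means a weaker inhibitor, a lower number a stronger inhibitor), and all three sit at the same boundary of the measurement. Compound 1 `COC(=O)Cn1nnc(Cc2ccc(-c3ccccc3)cc2)n1` gives a limit rather than a number in this assay, at > 50000 nM. Compound 2 `CN(C)C(=O)Cn1nnc(CNC(=O)c2ccc(-c3ccccc3)cc2)n1` likewise gives only a limit in this assay, at > 50000 nM. Compound 3 `CC(=O)Cn1nnnc1CNC(=O)c1ccc(-c2ccccc2)cc1` also returns a limit in this assay, at > 50000 nM. Where compound 2 stands is therefore not a point on a scale but the ceiling of what the assay reports, and the other two values shown share that ceiling, so that the limit of > 50000 nM in this assay, at which 3 of the 3 values shown sit, describes the whole set.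

The next compound, compound 4 `CC(=O)Cn1nnc(CNC(=O)c2ccc(-c3ccccc3)cc2)n1`, differs from compound 2 in one place: methyl in place of dimethylamino on a carbonyl carbon. Put another way, the (dimethylcarbamoyl)methyl arm of compound 2 becomes a 2-oxopropyl arm in compound 4, while the rest of the molecule stays as it is.

Within the data shown here, no measured pair in this set shows how a change of this kind moves the read-out, and every value shown is a limit. The expectation is that the step from compound 2 to compound 4 is a step that the limit leaves unreadable from compound 2 to compound 4, that is, nothing beyond the scatter, with compound 4 most likely reported as a limit as well. On that basis compound 4 is estimated at 60000 nM, within a range from 20000 nM to 200000 nM.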

Compound 4, half-maximal inhibitory concentration: > 50000 nM
Compound 4: only a limit was reported (the forecaster's own chance of this, stated with the estimate: 85%); the middle value does not contradict the limit.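

Among these compounds, compound 2 and compound 4 both return only a limit in this assay, so no step between them can be read. The compounds shown leave open how methyl in place of dimethylamino on a carbonyl carbon moves the read-out, and what any of these compounds' actual values are, since every value shown is the same limit: the limit of > 50000 nM in this assay, at which 4 of the 4 values shown sit.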